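A Second Fluorine on the Benzyl Group of Compound 3

The source may hold more compounds than are shown below. What is called first, only, known or untested is meant among the compounds shown, and "the series" means these compounds.

Of the compounds shown here, three built on a shared core have been tested in a functional assay on Bel7402/5-FU cells (Homo sapiens) for antiproliferative activity, read by MTT assay, with a stated time of 72 h; on this read-out higher numbers stand for weaker inhibition and lower numbers for stronger inhibition. Compound 1 (`C=C1C(=O)O[C@H]2[C@H]1CC/C(Cn1cc(Cn3cc(F)c(=O)[nH]c3=O)nn1)=C\CC[C@@]1(C)O[C@@H]21`) reads > 20000 nM, which is a limit of the assay and not a number. Compound 2 (`C=C1C(=O)O[C@H]2[C@H]1CC/C(COC(=O)CCC(=O)NCCCCCCNC(=O)Cn1cc(F)c(=O)[nH]c1=O)=C\CC[C@@]1(C)O[C@@H]21`) reads > 20000 nM, which is also a limit. Going by the values given here, compound 3 (`C=C1C(=O)O[C@H]2[C@H]1CC/C(COC(=O)Cn1cc(F)c(=O)n(Cc3ccc(F)cc3)c1=O)=C\CC[C@@]1(C)O[C@@H]21`) gives 1140 nM, the only actual number of the three.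

Compound 4 (`C=C1C(=O)O[C@H]2[C@H]1CC/C(COC(=O)Cn1cc(F)c(=O)n(Cc3c(F)cccc3F)c1=O)=C\CC[C@@]1(C)O[C@@H]21`) differs from compound 3 in one place: 2,6-difluorophenyl in place of 4-fluorophenyl on a saturated chain carbon bound to an aromatic nitrogen. Put simply, 2,6-difluorophenyl stands in place of 4-fluorophenyl on a saturated chain carbon bound to an aromatic nitrogen.

Among the compounds with values here, no measured pair in this small set shows what such a swap does, so compound 3, at 1140 nM, is the only anchor for a forecast. No shift beyond the usual scatter is expected, in either direction. The expected change is a 1.1-fold higher number from compound 3 to compound 4 (0.02 log units; within the scatter). Compound 4 is estimated at 1200 nM, with an expected range from 450 nM to 4000 nM.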

Compound 4, half-maximal inhibitory concentration: 4980 nM
Compound 4: middle estimate off by 4.2-fold (0.62 log units), on the low side; the whole stated range lies below it.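

In this assay the swap of 4-fluorobenzyl for 2,6-difluorobenzyl gives a 4.4-fold higher number from compound 3 to compound 4 (0.64 log units; beyond the scatter) and so moves toward weaker inhibition, by more than the usual scatter. Going by these compounds alone, this is the first step in the set that links one single change to a change in the read-out, and it shows that this position is sensitive to how the benzyl group is fluorinated, even though the ring itself stays the same. Nothing shown here explains why the number rose.

Going by these compounds, it remains open whether the rise follows from the number of fluorines or from where they sit. Plain benzyl, 4-chlorobenzyl or 2-fluorobenzyl at this position could show whether compound 3 is near a best case or merely one point in a wider range.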